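Cyclopropyl replaces 4-methylphenyl: a step near the assay limit

A few compounds are considered here, and "the series" means these few. Any claim that something is new, unique, unknown or untested is made for them only; others in the source may bear on it.

For the measured compounds named here, in a functional assay on MCF7 cells (Homo sapiens) for antiproliferative activity, read by MTT assay, with a stated time of 72 h (on this read-out lower numbers stand for stronger inhibition and higher numbers for weaker inhibition), compound 2 (`Cc1ccc(N2C(=O)COc3ccc(-c4cnc(Cl)c(NS(=O)(=O)c5ccc(F)cc5)c4)cc32)cc1`) gives 32600 nM, the only actual number so far. Compound 1 (`O=C1COc2ccc(-c3cnc(Cl)c(NS(=O)(=O)c4ccc(F)cc4)c3)cc2N1C1CCCCC1`) stands at > 40000 nM, which is a limit of the assay and not a number. Compound 3 (`O=C1COc2ccc(-c3cnc(Cl)c(NS(=O)(=O)c4ccc(F)cc4)c3)cc2N1C1CC1`) has cyclopropyl in place of 4-methylphenyl on an amide-type nitrogen in a ring. Going by the values given here, one measured step bears on this place: an at least 1.2-fold lower number from compound 1 to compound 2 (0.08 log units; that floor lies within the scatter), with 4-methylphenyl in place of cyclohexyl. No step beyond the scatter is therefore expected in this assay. The estimated step is a 1.1-fold higher number from compound 2 to compound 3 (0.03 log units; within the scatter). For compound 3 the expected value is 35000 nM, with an estimated range of 18000 nM to 60000 nM.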

Compound 3, half-maximal inhibitory concentration: 16700 nM
For compound 3 the middle estimate is 2.1-fold (0.32 log units) above the measured one, and the stated range ends above it.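

For the compounds shown here, on the amide-type nitrogen, cyclopropyl in place of cyclohexyl gives the first step at this place in this assay that clears the scatter: an at least 2.3-fold lower number from compound 1 to compound 3 (0.37 log units; beyond the scatter). The value of compound 1 is a limit of the assay and not a number: the limit of > 40000 nM in this assay, at which 1 of the 3 values shown sits. The other step, a 2.0-fold lower number from compound 2 to compound 3 (0.29 log units; within the scatter), stays within the scatter, so cyclopropyl and 4-methylphenyl cannot be told apart here.

All three groups shown on this nitrogen are rings of carbon only. From the compounds shown here alone, how an open chain such as methyl or ethyl, or a ring-bearing amine, would read at this place remains open.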